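This account rests on a few compounds, and the source may have more. Where it says the series, first, only, none or still open, it means among the compounds named here.

Two compounds built on a shared core have been through an ADME assay on HEK293 cells (Homo sapiens) for cytotoxicity, read by MTT assay, with a stated time of 48 h (a higher number here means a weaker inhibitor, a lower number a stronger inhibitor), so far. In this assay compound 1 (`COc1ccc(-c2nc(C)c(C(=O)CSc3nc(N)c(C#N)c(-c4ccccc4)n3)s2)cc1`) gives "not determined" (no result reported) and so offers nothing to compare against. Among the measured compounds shown here, compound 2 (`COc1ccc(-c2nc(C)c(C(=O)CSc3nc(-c4ccc(Cl)cc4)c(C#N)c(=O)[nH]3)s2)cc1`) gives 63000 nM as the only number available, which means it cannot yet be placed as high or low.

Compound 3 (`COc1ccc(-c2nc(C)c(C(=O)CSc3nc(-c4cccc(OC)c4)c(C#N)c(=O)[nH]3)s2)cc1`) is still waiting for its measurement. It keeps the core of compound 2 and differs in one place: 3-methoxyphenyl in place of 4-chlorophenyl on an aromatic carbon and this amounts to 3-methoxyphenyl in place of 4-chlorophenyl on an aromatic carbon, ortho to a cyano group.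

For the measured compounds named here, no measured pair here shows what a swap of this kind does, so nothing points firmly in either direction. An estimated step of a 1.1-fold lower number from compound 2 to compound 3 (0.02 log units; within the scatter) would stay within the usual scatter, so no real change is expected. Going by the values given here, the sole anchor is compound 2 at 63000 nM and the estimate therefore stays close to it, with a wide range to reflect how little is known. For compound 3 the estimated value is 60000 nM with an expected range from 25000 nM to 140000 nM across repeat measurements.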

Compound 3, half-maximal inhibitory concentration: 95400 nM
Estimate against measurement, compound 3: 1.6-fold (0.20 log units) below, within the range that was stated.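

In this assay, among the compounds shown here, the swap of 4-chlorophenyl for 3-methoxyphenyl on this aromatic carbon, ortho to a cyano group, gives a 1.5-fold higher number from compound 2 to compound 3 (0.18 log units; within the scatter) and provides the first measured step. Repeat measurements of a single compound could differ this much, so this pair shows no real difference between the two groups at this position. The exchange replaces a chlorine atom with a methoxy group and brings in one hydrogen-bond acceptor by the count, but no measurement shown here offers an explanation for how the two compounds compare.

The swap alters both the substituent and where it sits on the phenyl ring, so these compounds cannot separate the effect of one from the other, and two opposing effects cancelling out cannot be told apart from no effect at all. Also open, from the compounds shown here alone, is whether a different kind of group on that phenyl ring, such as an amine, a carboxylic acid or a longer chain, would shift the number beyond the usual scatter.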